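The source may report more compounds than this note shows. Statements on the series, on what has been measured and on what is new or still open speak of the compounds shown alone.

Compound 1 `CCCCCCCCCCCCCCCCCC[C@@H](N)[C@@H](O)CO` gives 32800 nM in a functional assay on A2780 cells (Homo sapiens) for inhibition; a higher number here means a weaker inhibitor, a lower number a stronger inhibitor. Compound 2 `CCCCCCCCCCCCCC[C@H](NC(=O)OC(C)(C)C)[C@H](O)CO` gives 30400 nM in this assay. Compound 3 `CCCCCCCCCCCCCC[C@@H](N)[C@@H](O)CO` gives 2630 nM in this assay.

Among these three numbers compound 1 stands highest. Its nearest neighbour is compound 2, whose value lies within the scatter of repeated measurements, so the two cannot be told apart. Among the compounds with values here, compound 3 lies furthest away: the change of a 12-fold lower number from compound 1 to compound 3 (1.10 log units; beyond the scatter) is the only single-point step that has been measured, and it concerns the length of the saturated chain, not the configuration of the stereocentres.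

Compound 4 `CCCCCCCCCCCCCCCCCC[C@H](N)[C@H](O)CO` is the subject of the present step. It differs from compound 1 in that (the two compounds have the same atoms and bonds and differ only in configuration as drawn: 2 of 2 stereo elements differ (all stereocentres are inverted: mirror images); a stereocentre at a saturated chain carbon is drawn R in compound 1 and S in compound 4; a stereocentre at a saturated chain carbon is drawn R in compound 1 and S in compound 4). Within the data shown here, no measured pair in this set shares that kind of difference, so the step from compound 1 to compound 3 gives no direct guide, and the gap between compound 1 and compound 2 likewise says nothing about mirror images. Among the measured compounds shown here, with no comparable step to lean on, the expectation is that the step of a 1.0-fold higher number from compound 1 to compound 4 (0.00 log units; within the scatter) will not go beyond the scatter, though the uncertainty is wide. Compound 4 is therefore estimated to give about 33000 nM, within a range from 8000 nM to 130000 nM.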

Compound 4, half-maximal inhibitory concentration: 2710 nM
Estimate against measurement, compound 4: 12-fold (1.09 log units) above; measured number below the stated range.
By their numbers in this assay, from the lowest: compounds 3 and 4 (each within the scatter of the next); then compounds 2 and 1 (each within the scatter of the next).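

In this assay configuration alone moves the number: inverting both stereocentres on the saturated chain carbons gives a 12-fold lower number from compound 1 to compound 4 (1.08 log units; beyond the scatter), a step of large size. Within the data shown here, until this result the only single-place step was the one in chain length, a 12-fold lower number from compound 1 to compound 3 (1.10 log units; beyond the scatter), and it said nothing about configuration; compound 4 now shows that the long chain of compound 1 does not by itself fix the high number, since compound 4 carries the same chain in the mirror-image form. The step can be assigned to the inversion and to nothing else, because no other difference separates the pair: the fact that compounds 1 and 4 differ only in the configuration as drawn.

The compounds shown leave open whether inverting just one of the two stereocentres would carry the step, or whether both inversions are needed, and whether the mirror image of compound 3 would move its number as well. They also leave open how either form of the chain would respond to an acetyl group on the amine or to a methyl ether on the terminal hydroxyl.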